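Swapping the ring on a shared sulfur linker

The compounds below may be only part of what the source reports. "The series", "measured", "known", "first", "only" and "open" are said of these compounds alone.

In a functional assay on HCT-116 cells (Homo sapiens) for inhibition, read by CCK-8 assay, with a stated time of 72 h, tested at 8 uM (a lower number here means less inhibition of growth, a higher number more inhibition of growth at the concentration tested), compound 2 `Nc1ccccc1NC(=O)c1ccc(CSc2cccc(F)c2)cc1` gives 81.4%, the highest of the three measured numbers. Compound 1 `Nc1ccccc1NC(=O)/C=C/c1ccc(CSc2cccc(F)c2)cc1` gives 3.22%, and compound 3 `Cc1ccc(SCc2ccc(/C=C/C(=O)Nc3ccccc3N)cc2)cc1` gives 4.93%. The difference between the core of compound 1 and the core of compound 2 is not broken down here. Compound 1 and compound 3 differ in a single change, (4-methylphenyl in place of 3-fluorophenyl on a sulfur); this change made a step of a number 1.7 percentage points higher from compound 1 to compound 3 (within the scatter) in this assay, so the two numbers do not differ beyond the scatter. Compound 4 `Cc1ccc(SCc2ccc(C(=O)Nc3ccccc3N)cc2)cc1` has not been measured. It differs from compound 2 by the same change, (4-methylphenyl in place of 3-fluorophenyl on a sulfur), made at the same place on the shared core of compound 2. Because the earlier step of a number 1.7 percentage points higher from compound 1 to compound 3 (within the scatter) stayed within the scatter, the same change is expected to make a step of only a number 3.4 percentage points lower from compound 2 to compound 4 (within the scatter) this time too. Compound 4 is therefore estimated to give about 78% in this assay, with a likely range from 60% to 92%. This expectation rests on one pair alone, compound 1 and compound 3, both far from compound 2, so it is held loosely.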

Compound 4, percent growth inhibition at one concentration: 84%
Compound 4: middle estimate off by 6 percentage points, on the low side; the range from low to high includes it.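

Putting 4-methylphenyl in place of 3-fluorophenyl on the sulfur made a step of a number 2.6 percentage points higher from compound 2 to compound 4 (within the scatter) in this assay. The change therefore left the number within the scatter on both cores, the one with low numbers and the one with high numbers: the same change on two cores in this assay, a number 1.7 percentage points higher (within the scatter) from compound 1 to compound 3 and a number 2.6 percentage points higher (within the scatter) from compound 2 to compound 4, 0.9 percentage points apart, within the scatter of two such steps

Among these compounds, this does not show that the two groups can be exchanged freely, since it rests on only two pairs, tested in one assay at one concentration, and a difference could still appear at other concentrations or in other tests.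

The compounds shown carry only these two substituted phenyl groups on the sulfur, so it remains open what a phenyl ring bearing an amine or a carboxylic acid, or a longer chain in place of the ring, would do there. From the compounds shown here alone, it also remains open whether an oxygen in place of the sulfur would leave the number unchanged on either core.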